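A few compounds are considered here, and "the series" means these few. Any claim that something is new, unique, unknown or untested is made for them only; others in the source may bear on it.

In a functional assay on NCI-H157 cells (Homo sapiens) for antiproliferative activity, read by sulforhodamine B assay, with a stated time of 48 h, tested at 10 uM (on this read-out lower numbers stand for less inhibition of growth and higher numbers for more inhibition of growth at the one concentration tested), compound 3 (`Oc1ccc(OCc2nn3c(-c4ccncc4)nnc3s2)cc1`) gives 60.9%. Compound 1 (`Fc1ccc(-c2nn3c(-c4ccncc4)nnc3s2)cc1Cl`), which has a different substitution on the shared core, gives 50.9%, within the scatter of compound 3. Compound 2 (`Fc1ccc(OCc2nn3c(-c4ccncc4)nnc3s2)cc1`) gives 28.5%. Going by the values given here, the one measured step is a number 32.4 percentage points higher from compound 2 to compound 3 (beyond the scatter), with hydroxy in place of fluoro on an aromatic carbon.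

Compound 4 (`COc1ccc(OCc2nn3c(-c4ccncc4)nnc3s2)cc1`) has not yet been measured. It differs from compound 3 by methyl in place of hydrogen on an oxygen on an aromatic ring, or hydroxy to methoxy. Among the compounds with values here, no measured step covers this exact change. The nearest evidence is a number 32.4 percentage points higher from compound 2 to compound 3 (beyond the scatter), which concerns the same aromatic position but compares hydroxy with fluoro, not with methoxy. Compound 4 also lacks the hydroxy, so part of that large step is expected to be lost, though not necessarily all of it. The expected step is a number 18.9 percentage points lower from compound 3 to compound 4 (beyond the scatter), in the downward direction. The estimate for compound 4 is 42%, with an expected range from 24% to 60%.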

Compound 4, percent growth inhibition at one concentration: 65.6%
The estimate for compound 4 lay 23.6 percentage points below the measured number; measured number outside the range, above it.
By their numbers in this assay, from the lowest: compound 2; then compounds 1, 3 and 4 (each within the scatter of the next, the first and the last beyond it).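

In this assay the hydrogen on the oxygen can be replaced by methyl with no readable change: the result is a number 4.7 percentage points higher from compound 3 to compound 4 (within the scatter) and so the free hydroxy is not required for the level of growth inhibition seen with compound 3. The large gain over fluoro is therefore not specific to hydroxy, as the series also shows a number 37.1 percentage points higher from compound 2 to compound 4 (beyond the scatter) with methoxy in place of fluoro on the same aromatic carbon. No available measurement accounts for the separation of fluoro from the two oxygen-linked groups.

Still open, going by these compounds, is how other groups at this aromatic position behave, such as an amine, a carboxylic acid or a longer chain on the oxygen such as ethoxy. Also open, on these data alone, is whether the grouping of hydroxy and methoxy holds at other concentrations, since only one concentration is read.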